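The source may hold more compounds than are shown below. What is called first, only, known or untested is meant among the compounds shown, and "the series" means these compounds.

Measured compounds:
Compound 1, `CN(C)c1cc2[nH]c(C3CCCCC3)nc2cc1NC(=O)c1cccs1`, in an ADME assay on Vero cells (Chlorocebus sabaeus) for cytotoxicity, read by resazurin assay, with a stated time of 3 days; a lower number here means a stronger inhibitor, a higher number a weaker inhibitor: > 100 ug/mL
Compound 2, `COCCOC(=O)Nc1cc2nc(C3CCCCC3)[nH]c2cc1N1CCCC1`, in this assay: > 100 ug/mL

Compound 1 reaches only a limit of the assay, > 100 ug/mL, and not a number. Compound 2 likewise gives only a limit, > 100 ug/mL, in this assay. Both values therefore sit at the limit of > 100 ug/mL in this assay, at which 2 of the 2 values shown sit, so compound 2 cannot be placed above or below compound 1; the numbers show no difference between them. Within the data shown here, no step between measured compounds is available.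

Compound 3, `Cc1ccc(C(=O)Nc2cc3nc(C4CCCCC4)[nH]c3cc2N2CCCC2)cc1`, is the next compound, not yet measured in this assay. It differs from compound 2 by 4-methylphenyl in place of 2-methoxyethoxy on a carbonyl carbon. Since compound 2 gives only a limit, > 100 ug/mL, compound 3 is expected to behave the same way, with the step that the limit leaves unreadable from compound 2 to compound 3 amounting to none beyond the scatter. Compound 3 is therefore estimated at 120 ug/mL, within a range from 50 ug/mL to 300 ug/mL, and most likely it will again report only a limit.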

Compound 3, half-maximal inhibitory concentration: > 100 ug/mL
Compound 3: a limit, no number; the forecaster's own chance of this, stated with the estimate: 70%; the middle value is on the limit's open side.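

In this assay, among these compounds, compound 3 gives only a limit, > 100 ug/mL and no number, so no step from compound 2 to compound 3 can be read: (the limit of > 100 ug/mL in this assay, at which 3 of the 3 values shown sit). The compounds shown leave open how 2-methoxyethoxy and 4-methylphenyl on a carbonyl carbon compare in this assay and what actual number any of the three compounds would give.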